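The source may hold more compounds than are shown below. What is called first, only, known or untested is meant among the compounds shown, and "the series" means these compounds.

Of the compounds shown here, three have been measured for agonist activity in a functional assay on CHO cells for agonist activity at Free fatty acid receptor 2 (Homo sapiens), read by cAMP accumulation; on this read-out lower numbers stand for stronger inhibition and higher numbers for weaker inhibition. Compound 1 `CC(C)[C@H](C(=O)Nc1nc2cc(Cl)ccc2o1)c1ccc(Cl)cc1` gives 4300 nM. Compound 2 `CC(C)(C)[C@H](C(=O)Nc1ncc(C(F)(F)F)s1)c1ccc(Cl)cc1`, which carries a trifluoromethyl on its five-membered aromatic ring, gives 1500 nM. Compound 3 `CSc1cnc(NC(=O)[C@H](c2ccc(Cl)cc2)C(C)(C)C)s1`, where that trifluoromethyl is replaced by methylsulfanyl, gives 500 nM, the lowest number of the three; compound 2 is the nearest to it and compound 1 the furthest. The only single-point step among these three is a 3.0-fold lower number from compound 2 to compound 3 (0.48 log units; beyond the scatter).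

Compound 4 `CC(C)(C)[C@H](C(=O)Nc1ncc(C(O)(C(F)(F)F)C(F)(F)F)s1)c1ccc(Cl)cc1` has not yet been measured. It differs from compound 3 in one place: 2,2,2-trifluoro-1-hydroxy-1-(trifluoromethyl)ethyl in place of methylsulfanyl on an aromatic carbon. The group that enters is a large one, carrying a hydroxyl beside two trifluoromethyls, and sits on the aromatic carbon next to the ring sulfur.

Going by the values given here, the one measured step that bears on this position shows that swapping trifluoromethyl for methylsulfanyl moved the number by a modest amount. Among the compounds with values here, no measured compound carries anything resembling the group that enters, so there is no direct guide to its effect. Given this, the expectation for compound 4 is a number close to that of compound 3, with a 1.6-fold higher number from compound 3 to compound 4 (0.20 log units; within the scatter) expected to lie within the scatter or only slightly beyond it in either direction. Compound 4 is estimated at 800 nM, with a plausible range from 250 nM to 3000 nM.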

Compound 4, half-maximal inhibitory concentration: 1200 nM
Compound 4: the middle estimate sits 1.5-fold (0.18 log units) below what was measured; the range from low to high includes it.
By their numbers in this assay, from the lowest: compound 3; then compounds 4 and 2 (each within the scatter of the next); then compound 1.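

At the aromatic carbon next to the ring sulfur, in this assay, 2,2,2-trifluoro-1-hydroxy-1-(trifluoromethyl)ethyl in place of methylsulfanyl gives a 2.4-fold higher number from compound 3 to compound 4 (0.38 log units; beyond the scatter) and so places methylsulfanyl, for now, as the group with the lowest number of the three tried at this position. Set against trifluoromethyl, the same large group gives a 1.3-fold lower number from compound 2 to compound 4 (0.10 log units; within the scatter) and cannot be told apart from it here, so the hydroxyl and the second trifluoromethyl together leave the number about where a single trifluoromethyl puts it. The data shown offer nothing that explains either step.

Still open, going by these compounds, is whether methylsulfanyl owes its lower number to the sulfur or to the methyl, which ethylsulfanyl, with a longer chain, or methoxy, with oxygen in place of sulfur, could help to separate. On these data alone, it is also open how an amine, a carboxylic acid or a simple hydroxymethyl would compare at this position with the three groups seen so far.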